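Changing the amide substituent of compound 3

The source may report more compounds than this note shows. Statements on the series, on what has been measured and on what is new or still open speak of the compounds shown alone.

Measured in a functional assay on MCF7 cells (Homo sapiens) for antiproliferative activity, read by sulforhodamine B assay, with a stated time of 72 h; on this read-out lower numbers stand for stronger inhibition and higher numbers for weaker inhibition:
Compound 1 `COc1ccc(NC(=O)Cn2nc(-c3ccccc3)c3ccccc3c2=O)cc1`: 77000 nM
Compound 2 `O=C(Cn1nc(-c2ccccc2)c2ccccc2c1=O)Nc1ccccc1Cl`: 30000 nM
Compound 3 `COc1ccc(NC(=O)Cn2nc(Cc3ccccc3)c3ccccc3c2=O)cc1`: 62000 nM

Compound 3 lies within the scatter of compound 1, while compound 2 gives a lower number than either of them. The next compound, compound 4 `O=C(Cn1nc(Cc2ccccc2)c2ccccc2c1=O)Nc1cccc(C(F)(F)F)c1`, has 3-(trifluoromethyl)phenyl in place of 4-methoxyphenyl on an amide-type nitrogen.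

The closest evidence is a 2.6-fold lower number from compound 1 to compound 2 (0.41 log units; beyond the scatter), a modest change in which 2-chlorophenyl replaces 4-methoxyphenyl at that same kind of nitrogen. The other measured change, a 1.2-fold lower number from compound 1 to compound 3 (0.09 log units; within the scatter), stays within the scatter, which suggests that the benzyl group of compound 3 need not alter how the amide change carries over. Among the compounds with values here, no measured compound contains the 3-(trifluoromethyl)phenyl group, so this comparison remains loose.

A modest shift toward stronger inhibition is therefore expected, with an estimated 2.2-fold lower number from compound 3 to compound 4 (0.35 log units; beyond the scatter). The expected value for compound 4 is 28000 nM, within an estimated range of 11000 nM to 65000 nM.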

Compound 4, half-maximal inhibitory concentration: 3850 nM
The estimate for compound 4 lay 7.3-fold (0.86 log units) above the measured number; the measured number lies below the stated range.
By their numbers in this assay, from the lowest: compound 4; then compound 2; then compounds 3 and 1 (each within the scatter of the next).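

In this assay, within the data shown here, the step of a 16-fold lower number from compound 3 to compound 4 (1.21 log units; beyond the scatter) is large, whereas the only earlier change at an amide-type nitrogen, a 2.6-fold lower number from compound 1 to compound 2 (0.41 log units; beyond the scatter), was modest. Among these compounds, the aryl group on this nitrogen can therefore move the number much further than the earlier compounds showed. That reach also exceeds the change of phenyl to benzyl on an aromatic carbon, a 1.2-fold lower number from compound 1 to compound 3 (0.09 log units; within the scatter), which stayed within the scatter.

The compounds shown leave open whether the trifluoromethyl group itself or its place on the ring accounts for the step, and whether 3-(trifluoromethyl)phenyl would do the same alongside phenyl instead of benzyl. Going by these compounds, how an amine or a carboxylic acid on this aryl ring would compare also remains open. No measurement here explains the size of this step.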